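From phenyl to 4-methoxyphenyl on the shared core

The source may hold more compounds than are shown below. What is called first, only, known or untested is meant among the compounds shown, and "the series" means these compounds.

Measured in a functional assay on HT-29 cells (Homo sapiens) for inhibition, read by MTT assay, with a stated time of 48 h; a higher number here means a weaker inhibitor, a lower number a stronger inhibitor:
Compound 1 `COc1cc(-c2cc(-c3ccc(Cl)cc3)nc(-c3ccccc3)n2)cc(OC)c1OC`: 6230 nM
Compound 2 `COc1ccc(-c2cc(-c3cc(OC)c(OC)c(OC)c3)nc(-c3ccccc3)n2)c(OC)c1`: > 25000 nM, a limit of the assay
Compound 3 `COc1cc(-c2cc(-c3ccccc3)nc(-c3ccccc3)n2)cc(OC)c1OC`: 7930 nM

Compound 3 stands at 7930 nM. Among the measured compounds shown here, the one numerical comparison available is a 1.3-fold higher number from compound 1 to compound 3 (0.10 log units; within the scatter), within the scatter. Compound 4 `COc1ccc(-c2cc(-c3cc(OC)c(OC)c(OC)c3)nc(-c3ccccc3)n2)cc1` has methoxy in place of hydrogen on an aromatic carbon, para to a large group, turning phenyl into 4-methoxyphenyl: methoxy in place of hydrogen on an aromatic carbon. For the measured compounds named here, two measured steps bear on this change. The step of a 1.3-fold higher number from compound 1 to compound 3 (0.10 log units; within the scatter), hydrogen in place of chloro, stays within the scatter. The step of an at least 3.1-fold lower number from compound 2 to compound 3 (0.49 log units; beyond the scatter), phenyl in place of 2,4-dimethoxyphenyl, lies beyond it. A small rise in the number is therefore expected, and the expected step is a 1.4-fold higher number from compound 3 to compound 4 (0.14 log units; within the scatter). For compound 4 the estimate is 11000 nM, with an expected range from 4500 nM to 25000 nM.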

Compound 4, half-maximal inhibitory concentration: 4230 nM
Estimate against measurement, compound 4: 2.6-fold (0.42 log units) above; measured number below the stated range.
By their numbers in this assay, from the lowest: compounds 4, 1 and 3 (each within the scatter of the next). At a limit, above all of these: compound 2.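

In this assay, methoxy at this position, para to a large group, leaves the number level with both hydrogen (a 1.9-fold lower number from compound 3 to compound 4 (0.27 log units; within the scatter)) and chloro (a 1.5-fold lower number from compound 1 to compound 4 (0.17 log units; within the scatter)), so none of these three groups separates from the others here. Among the compounds shown here, the one step beyond the scatter is the change from the 2,4-dimethoxyphenyl group to 4-methoxyphenyl (an at least 5.9-fold lower number from compound 2 to compound 4 (0.77 log units; beyond the scatter)). The value of compound 2 is a limit of the assay: the limit of > 25000 nM in this assay, at which 1 of the 4 values shown sits.

Going by these compounds, how far that step truly reaches stays open. So does whether an amine or a carboxylic acid at this position would move the number beyond the scatter.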